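The source may report more compounds than this note shows. Statements on the series, on what has been measured and on what is new or still open speak of the compounds shown alone.

Compound 1 `Cc1cc(=O)n(-c2ccccc2C(F)(F)F)nc1C(=O)Nc1ccc(Oc2ncnc3ccsc23)cc1` gives 5550 nM in a functional assay on MCF7 cells (Homo sapiens) for cytotoxicity, read by MTT assay, with a stated time of 72 h; on this read-out higher numbers stand for weaker inhibition and lower numbers for stronger inhibition. Compound 3 `Cc1cc(=O)n(-c2ccc(F)c(F)c2)nc1C(=O)Nc1ccc(Oc2ncnc3ccsc23)cc1` gives 5550 nM in this assay, and compound 2 `Cc1cc(=O)n(-c2cccc(F)c2)nc1C(=O)Nc1ccc(Oc2ncnc3ccsc23)cc1` gives 6410 nM. Compound 1 thus stands level with compound 3 at the digits shown, the two together the lowest of the three numbers, though every step among them is within the scatter: a 1.2-fold higher number from compound 1 to compound 2 (0.06 log units; within the scatter), no change at the digits printed from compound 1 to compound 3 (within the scatter) and a 1.2-fold lower number from compound 2 to compound 3 (0.06 log units; within the scatter). Compound 4 `Cc1cc(=O)n(-c2ccccc2C(F)(F)F)nc1C(=O)Nc1ccc(Oc2ncnc3sccc23)cc1` differs from compound 1 by a group of 9 heavy atoms (6 carbon, 2 nitrogen, 1 sulfur; one five-membered aromatic ring with 1 hetero atom, one six-membered aromatic ring with 2 hetero atoms) in place of a group of 9 heavy atoms (6 carbon, 2 nitrogen, 1 sulfur; one five-membered aromatic ring with 1 hetero atom, one six-membered aromatic ring with 2 hetero atoms), on an oxygen on an aromatic ring. Within the data shown here, none of the measured steps bears on this part of the molecule; all three alter the group on the aromatic nitrogen and stay within the scatter. No step beyond the scatter in this assay, in either direction, is therefore expected. Compound 4 is expected to give 5500 nM, within 2500 nM to 12000 nM. The expected step is a 1.0-fold lower number from compound 1 to compound 4 (0.00 log units; within the scatter), within the scatter.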

Compound 4, half-maximal inhibitory concentration: > 40000 nM
Compound 4 was reported as a limit; the forecaster's own chance of this, stated with the estimate: 5%; middle value at least 7.2-fold (0.86 log units) away from the limit.
By their numbers in this assay, from the lowest: compounds 1, 3 and 2 (each within the scatter of the next). At a limit, above all of these: compound 4.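

In this assay, the group on the oxygen on an aromatic ring proves far less tolerant than the group on the aromatic nitrogen, whose changes all stayed within the scatter: joining the same atoms differently gives an at least 7.2-fold higher number from compound 1 to compound 4 (0.85 log units; beyond the scatter). The two groups have the same ring types and the same donor and acceptor counts, so these counts do not separate compound 1 from compound 4. The result for compound 4 is a limit, not a number: the limit of > 40000 nM in this assay, at which 1 of the 4 values shown sits.

Why the rejoined group costs so much activity stays open, as does whether it does so with 3-fluorophenyl or 3,4-difluorophenyl on the aromatic nitrogen. Also open, from the compounds shown here alone, is how an amine or a carboxylic acid on the group on the oxygen would read.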